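Replacing Cyclopropyl With 4-Bromobenzyl on the Amine

The source may hold more compounds than are shown below. What is called first, only, known or untested is meant among the compounds shown, and "the series" means these compounds.

Of the compounds shown here, three sharing one core have been measured in a functional assay on HT-29 cells (Homo sapiens) for inhibition, read by MTT assay, with a stated time of 72 h; a lower number here means a stronger inhibitor, a higher number a weaker inhibitor. Compound 1 `COc1cc(Oc2cccc(Nc3ccccc3)c2)cc(OC)c1CNCc1ccc(C)cc1` gives 3880 nM, compound 2 `COc1ccc(CCCNCc2c(OC)cc(Oc3cccc(Nc4ccccc4)c3)cc2OC)cc1` gives 3320 nM, and compound 3 `COc1cc(Oc2cccc(Nc3ccccc3)c2)cc(OC)c1CNC1CC1` gives 12300 nM, the highest of the three numbers. The steps of a 3.2-fold higher number from compound 1 to compound 3 (0.50 log units; beyond the scatter) and a 3.7-fold higher number from compound 2 to compound 3 (0.57 log units; beyond the scatter) both end at a higher number, that is a weaker inhibitor, when cyclopropyl enters on the amine nitrogen. Compound 4 `COc1cc(Oc2cccc(Nc3ccccc3)c2)cc(OC)c1CNCc1ccc(Br)cc1` carries 4-bromobenzyl in place of cyclopropyl on an amine nitrogen. Because compound 1 gives 3880 nM with a 4-methylbenzyl group on that same nitrogen, a modest fall in number, opposite to those two steps, is expected, namely a 3.4-fold lower number from compound 3 to compound 4 (0.53 log units; beyond the scatter). Compound 4 is therefore estimated at 3600 nM, within a range from 1500 nM to 8500 nM.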

Compound 4, half-maximal inhibitory concentration: 3060 nM
Compound 4: middle estimate off by 1.2-fold (0.07 log units), on the high side; the range from low to high includes it.
By their numbers in this assay, from the lowest: compounds 4, 2 and 1 (each within the scatter of the next); then compound 3.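

In this assay, the step (a 4.0-fold lower number from compound 3 to compound 4 (0.60 log units; beyond the scatter)) shows that cyclopropyl's weaker result also holds against a third group on this amine nitrogen, 4-bromobenzyl. Bromo in place of methyl on the aromatic ring gives no difference beyond the scatter (a 1.3-fold lower number from compound 1 to compound 4 (0.10 log units; within the scatter)), and neither does the comparison with the longer chain (a 1.1-fold lower number from compound 2 to compound 4 (0.04 log units; within the scatter)), so compounds 1, 2 and 4 stay level while compound 3 stands apart. Nothing available explains this difference. From the compounds shown here alone, whether a larger saturated ring such as cyclohexyl would match the benzyl groups stays open. So does the effect of a carboxylic acid on their aromatic ring.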